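The source may report more compounds than this note shows. Statements on the series, on what has been measured and on what is new or still open speak of the compounds shown alone.

Measured so far:
- compound 1, `O=C1C(Nc2cccc(Cl)c2)=CC(=O)c2c1nc1n2[C@H]2OC[C@@H](O)[C@H]2OC1`: 1530 nM
- compound 2, `CCc1ccc(NC2=CC(=O)c3nc4n(c3C2=O)[C@H]2OC[C@@H](O)[C@H]2OC4)cc1`: 1290 nM

In a functional assay on MGC-803 cells (Homo sapiens) for inhibition, read by sulforhodamine B assay (on this read-out higher numbers stand for weaker inhibition and lower numbers for stronger inhibition), compound 1 gives the higher of the two numbers, with compound 2 nearest, a gap within the scatter, so no order between the two can be read from the values. Both carry an aryl group on the amine nitrogen of the shared core and land in the same region of this assay.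

Compound 3, `COc1ccccc1NC1=CC(=O)c2c(nc3n2[C@H]2OC[C@@H](O)[C@H]2OC3)C1=O`, has not yet been measured. It differs from compound 1 in one place: 2-methoxyphenyl in place of 3-chlorophenyl on an amine nitrogen. Within the data shown here, no step between measured compounds covers this kind of exchange, so the direction cannot be taken from the data; both aryl variants seen so far sit close together, which suggests no step beyond the scatter. The expected step of a 1.0-fold higher number from compound 1 to compound 3 (0.02 log units; within the scatter) is therefore set near none. Compound 3 is estimated at 1600 nM, with a range of 700 nM to 3600 nM.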

Compound 3, half-maximal inhibitory concentration: 1670 nM
Estimate against measurement, compound 3: 1.0-fold (0.02 log units) below, and the stated range covers the measured number.
By their numbers in this assay, from the lowest: compounds 2, 1 and 3 (each within the scatter of the next).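

Among these compounds, the exchange of 3-chlorophenyl for 2-methoxyphenyl on the amine nitrogen gives a 1.1-fold higher number from compound 1 to compound 3 (0.04 log units; within the scatter) in this assay as the first readable step at this place. Here the group that enters has 1 hydrogen-bond acceptor and the group that leaves has 0, and the chlorine gives way to an oxygen, yet the step shows no change in this pair. No independent measurement available here bears on this result.

All the compounds shown keep a substituted phenyl ring on this nitrogen, so it remains open whether a larger step appears with an unsubstituted phenyl, a benzyl group or a short alkyl chain. As far as these compounds go, the effect of a phenyl ring carrying a carboxylic acid or a basic amine also remains open.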